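A few compounds are considered here, and "the series" means these few. Any claim that something is new, unique, unknown or untested is made for them only; others in the source may bear on it.

In a functional assay on MDA-MB-231 cells (Homo sapiens) for inhibition, read by sulforhodamine B assay, tested at 10 uM (on this read-out lower numbers stand for less inhibition and higher numbers for more inhibition at the one concentration tested (going by the name of the read-out)), compound 1, with the structure `COC(=O)CC(=O)N1N=C(c2ccc(-n3cncn3)cc2)CC1c1ccc(N(C)C)cc1`, gives 6.8%. Compound 2, with the structure `CN(C)c1ccc(C2CC(c3ccc(-n4cncn4)cc3)=NN2C(=O)c2ccc(F)cc2)cc1`, differs from compound 1 by 4-fluorophenyl in place of (methoxycarbonyl)methyl on a carbonyl carbon, and in this assay compound 2 gives 12.5%; the step of a number 5.7 percentage points higher from compound 1 to compound 2 (within the scatter). Compound 3, with the structure `COC(=O)CC(=O)N1N=C(c2ccc(-n3ccnc3)cc2)CC1c1ccc(N(C)C)cc1`, carries a different core: its difference from compound 1 is 1H-imidazol-1-yl in place of 1H-1,2,4-triazol-1-yl on an aromatic carbon. In this assay compound 3 gives 2.3%, and the step of a number 4.5 percentage points lower from compound 1 to compound 3 (within the scatter). Compound 3 thus shows the lowest of the three numbers, though its value and that of compound 1 lie within the scatter of each other, while the gap to compound 2 lies beyond it.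

Compound 4, with the structure `CN(C)c1ccc(C2CC(c3ccc(-n4ccnc4)cc3)=NN2C(=O)c2ccc(F)cc2)cc1`, has not been measured in this assay. It is related to compound 3 by 4-fluorophenyl in place of (methoxycarbonyl)methyl on a carbonyl carbon, the same change that relates compound 1 to compound 2, since the place is described in the same words in both cases. Among the compounds considered here that change occurs twice in all, and the one measured instance is a number 5.7 percentage points higher from compound 1 to compound 2 (within the scatter). Among the measured compounds shown here, because the one measured instance of this change reads a number 5.7 percentage points higher from compound 1 to compound 2 (within the scatter), a step of like size is expected here, namely a number 5.7 percentage points higher from compound 3 to compound 4 (within the scatter); this rests on nothing more than that single observed pair. On that basis compound 4 is expected to give about 8% in this assay, with a range estimated from 0% to 20%.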

Compound 4, a percentage reported as inhibition, at one concentration (the size of the read-out at that concentration, not a potency): 9.4%
The estimate for compound 4 lay 1.4 percentage points below the measured number, and the stated range covers the measured number.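

In this assay, the exchange of (methoxycarbonyl)methyl for 4-fluorophenyl on a carbonyl carbon gives a number 7.1 percentage points higher from compound 3 to compound 4 (within the scatter), and this matches its earlier instance: the same change on two cores in this assay, a number 5.7 percentage points higher (within the scatter) from compound 1 to compound 2 and a number 7.1 percentage points higher (within the scatter) from compound 3 to compound 4, 1.4 percentage points apart, within the scatter of two such steps. The exchange of 1H-1,2,4-triazol-1-yl for 1H-imidazol-1-yl on an aromatic carbon, seen here as a number 3.1 percentage points lower from compound 2 to compound 4 (within the scatter), likewise reads much the same in both of its instances: the same change on two cores in this assay, a number 4.5 percentage points lower (within the scatter) from compound 1 to compound 3 and a number 3.1 percentage points lower (within the scatter) from compound 2 to compound 4, 1.4 percentage points apart, within the scatter of two such steps. Within these four compounds, each change thus carries from one core to the other with a step of like size, but all four steps lie within the scatter, and each change is seen on only two cores, so this agreement does not show that either change has a real effect on inhibition or that it would carry to further cores.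

The compounds shown leave open whether a carboxylic acid, a benzyl group or a longer alkyl chain on that carbonyl carbon would give a step beyond the scatter. They also leave open whether a tetrazole or a simple amine on that aromatic carbon would do so, and whether either exchange would then behave alike on both cores.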